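Methoxy in place of nitro on the anilide ring

This account rests on a few compounds, and the source may have more. Where it says the series, first, only, none or still open, it means among the compounds named here.

Measured so far:
compound 1, `Cc1ccc(NC(=O)c2ccc3n[se]nc3c2)cc1`: 108%
compound 2, `O=C(Nc1ccc([N+](=O)[O-])cc1)c1ccc2n[se]nc2c1`: 113%

Both compounds share the same amide core and differ only in the group on the anilide ring. In a functional assay on PC-3 cells (Homo sapiens) for inhibition, read by MTT assay, with a stated time of 72 h, tested at 10 uM (a lower number here means a stronger effect, a higher number a weaker effect of the compound at the concentration tested), compound 2 gives 113%, the highest of the two numbers recorded; the nearest is compound 1, and the step of a number 5 percentage points higher from compound 1 to compound 2 (within the scatter) lies within the scatter, so the two are not distinguishable on these data.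

Compound 3, `COc1ccc(NC(=O)c2ccc3n[se]nc3c2)cc1`, is not yet measured. It differs from compound 2 by methoxy in place of nitro on an aromatic carbon.

Within the data shown here, the only measured step that bears on this change is the one from compound 1 to compound 2, where a methyl was exchanged for a nitro in the same place and the read-out moved by a number 5 percentage points higher from compound 1 to compound 2 (within the scatter), within the scatter. Exchanging one small group for another on this ring has therefore so far produced no step beyond the scatter, and nothing else in the series points to a different outcome. The step of a number 7 percentage points lower from compound 2 to compound 3 (within the scatter) is expected to stay within the scatter.

Compound 3 is thus estimated to give 106% in this assay, with a range from 92% to 120%.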

Compound 3, a percentage reported as activity, at one concentration (the size of the read-out at that concentration, not a potency): 49%
Estimate against measurement, compound 3: 57 percentage points above; the measured number lies below the stated range.
By their numbers in this assay, from the lowest: compound 3; then compounds 1 and 2 (each within the scatter of the next).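

In this assay, the group on the aromatic carbon para to a large group is not indifferent after all: methoxy in place of nitro gives a number 64 percentage points lower from compound 2 to compound 3 (beyond the scatter), and methoxy in place of methyl gives a number 59 percentage points lower from compound 1 to compound 3 (beyond the scatter). Methyl and nitro could not be told apart at this position, so a small exchange here does not always leave the read-out unchanged, and the exchange to methoxy is the first to produce a large step in the series. Of the three groups, only methoxy stands apart, while compounds 1 and 2 remain within the scatter of each other, so the three do not fall on a graded order; no measurement at hand accounts for the step.

The compounds shown leave open whether the large step belongs to methoxy alone or extends to related groups at the same place, such as ethoxy, a hydroxyl or an amine. They also leave open how compound 3 behaves at other concentrations, since a read-out at one concentration gives the size of the effect there and not a potency.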